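A pyrazole swap at one nitrogen of the shared core

The source may report more compounds than this note shows. Statements on the series, on what has been measured and on what is new or still open speak of the compounds shown alone.

Compound 1 `O=C(Nc1ccc(Nc2nccc(NC3CCCCC3)n2)cc1)Nc1ccc(Cl)c(C(F)(F)F)c1` gives 10800 nM here
Compound 2 `O=C(Nc1ccc(Nc2nccc(Nc3ccc(Cl)cc3)n2)cc1)Nc1ccc(Cl)c(C(F)(F)F)c1` gives 12800 nM here

Both values come from a functional assay on MCF7 cells (Homo sapiens) for antiproliferative activity, read by MTT assay, with a stated time of 72 h (on this read-out higher numbers stand for weaker inhibition and lower numbers for stronger inhibition), and they lie within the scatter of each other, so compound 2 stands level with compound 1 on these numbers. Compound 3 `Cn1cc(Nc2ccnc(Nc3ccc(NC(=O)Nc4ccc(Cl)c(C(F)(F)F)c4)cc3)n2)cn1` has not been measured yet. It differs from compound 2 by one change 1-methyl-1H-pyrazol-4-yl in place of 4-chlorophenyl on a nitrogen on an aromatic ring which in words is 1-methyl-1H-pyrazol-4-yl in place of 4-chlorophenyl on a nitrogen on an aromatic ring.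

Among the compounds with values here, only one measured step bears on this place. Putting 4-chlorophenyl in place of cyclohexyl gave a 1.2-fold higher number from compound 1 to compound 2 (0.07 log units; within the scatter) and so left the number within the scatter. Within the data shown here, that is a single step, and no measured compound carries a five-membered ring here, so it is only a modest guide. Even so, it gives no reason to expect a large move in either direction in this assay for this swap. The estimated step is a 1.2-fold lower number from compound 2 to compound 3 (0.07 log units; within the scatter) and no change beyond the scatter is expected. For compound 3 the estimate is 11000 nM with an expected range from 4000 nM to 30000 nM in this read-out.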

Compound 3, half-maximal inhibitory concentration: 9770 nM
Compound 3: middle estimate off by 1.1-fold (0.05 log units), on the high side; the measured number falls inside the stated range.
By their numbers in this assay, from the lowest: compounds 3, 1 and 2 (each within the scatter of the next).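

In this assay, compound 3 stands level with both earlier compounds: 1-methyl-1H-pyrazol-4-yl in place of 4-chlorophenyl gives a 1.3-fold lower number from compound 2 to compound 3 (0.12 log units; within the scatter), and 1-methyl-1H-pyrazol-4-yl in place of cyclohexyl gives a 1.1-fold lower number from compound 1 to compound 3 (0.04 log units; within the scatter). This nitrogen on the aromatic ring has now carried a five-membered aromatic ring with 2 hetero atoms as well as the two six-membered rings, and among these compounds, the swap from 0 to 2 hydrogen-bond acceptors in the group comes with no difference beyond the scatter. No supporting measurement is available to explain why these three groups read alike.

From the compounds shown here alone, all three compounds carry a ring at this position, so it remains open whether an open-chain group, such as a longer alkyl chain, or a group ending in an amine or a carboxylic acid would give a number beyond the scatter. Going by these compounds, it also remains open whether the level reading would hold if another part of the shared core were changed at the same time.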